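Fluoro for Azido on a Nucleoside Core: Cytotoxicity Outlook

The source may hold more compounds than are shown below. What is called first, only, known or untested is meant among the compounds shown, and "the series" means these compounds.

Compound 1 `CC(C)(C)OC(=O)NOc1nc(N)nc2c1ncn2[C@@H]1O[C@H](CO)[C@@H](O)[C@@]1(C)O` gives in an ADME assay on Vero cells (Chlorocebus sabaeus) for cytotoxicity, with a stated time of 3 days; a lower number here means that less compound is tolerated, a higher number that more compound is tolerated > 100000 nM, a limit of the assay.
Compound 2 `C[C@@]1(O)[C@H](O)[C@@H](CO)O[C@H]1n1cnc2c(ONC(=O)OCc3ccccc3)nc(N)nc21` gives in this assay > 100000 nM, again a limit.
Compound 3 `C[C@@]1(O)[C@H](O)[C@@H](CO)O[C@H]1n1cnc2c(N)nc(N=[N+]=[N-])nc21` gives in this assay > 100000 nM, also a limit.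

Compound 3 therefore stands only at a limit in this assay, and all three compounds sit at the same limit (the limit of > 100000 nM in this assay, at which 3 of the 3 values shown sit). Within the data shown here, the single measured step, a step that the two limits leave unreadable from compound 1 to compound 2, stays unreadable. Compound 4 `C[C@@]1(O)[C@H](O)[C@@H](CO)O[C@H]1n1cnc2c(N)nc(F)nc21` differs from compound 3 by fluoro in place of azido on an aromatic carbon. Among the measured compounds shown here, no measured step bears on this change, and the one step available gives no readable size. Compound 4 is therefore expected to stay at the limit, with an estimated step of a number no higher from compound 3 to compound 4 (the limit leaves the size open). For compound 4 the estimate in this assay is 100000 nM, ranging from 50000 nM to 300000 nM.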

Compound 4, half-maximal cytotoxic concentration: > 100000 nM
Compound 4 was reported as a limit; the forecaster's own chance of this, stated with the estimate: 75%; the middle value sits exactly at the limit.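

Compound 3 and compound 4 both stand at a limit in this assay, so the change from azido to fluoro yields no readable step. The compounds shown leave open what concentration would prove cytotoxic for any of them: the limit of > 100000 nM in this assay, at which 4 of the 4 values shown sit.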